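The compounds below may be only part of what the source reports. "The series", "measured", "known", "first", "only" and "open" are said of these compounds alone.

Measured compounds:
- compound 1, `Cc1ccc2oc(-c3c4c(N)n[nH]c(=O)c4nn3-c3ccccc3)c(C)c2c1`: 416 nM
- compound 2, `C=CC(=O)Nc1ccc(-n2nc3c(=O)[nH]nc(N)c3c2-c2oc3ccc(C)cc3c2C)cc1`: < 0.3 nM
- compound 3, `C=CC(=O)NCc1ccc(-n2nc3c(=O)[nH]nc(N)c3c2-c2oc3ccc(C)cc3c2C)cc1`: 0.6 nM

In a functional assay on KG-1 cells (Homo sapiens) for antiproliferative activity, read by CCK-8 assay, with a stated time of 72 h (on this read-out lower numbers stand for stronger inhibition and higher numbers for weaker inhibition), compound 1 gives 416 nM. This is the highest of the two numbers available, and compound 3 sits nearest with 0.6 nM, the gap being a 690-fold lower number from compound 1 to compound 3 (2.84 log units; beyond the scatter). For compound 2 the assay reports only a limit, < 0.3 nM (the limit of < 0.3 nM in this assay, at which 1 of the 3 values shown sits); the step of an at least 1300-fold lower number from compound 1 to compound 2 (3.14 log units; beyond the scatter) therefore is itself a bound. Between compound 2 and compound 3 the step of an at least 2.0-fold higher number from compound 2 to compound 3 (0.30 log units; that floor lies within the scatter) is likewise a bound and stays within the scatter.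

Compound 4, `Cc1c(-c2c3c(N)n[nH]c(=O)c3nn2-c2ccccc2)oc2ccccc12`, is not yet measured. It differs from compound 1 by hydrogen in place of methyl on an aromatic carbon: a methyl leaves and hydrogen enters on an aromatic carbon of a six-membered aromatic ring of carbon only, part of a fused or bridged system of two rings, meta to a fused ring and para to a fused ring. Among the measured compounds shown here, none of the measured steps touches this methyl; all three involve the (vinylcarbonyl)amino or ((vinylcarbonyl)amino)methyl groups on another aromatic carbon, and they are large. For the measured compounds named here, no measured step, then, bears directly on the step from compound 1 to compound 4. Removing a single carbon with no donors or acceptors is expected to move the number little, if at all, beyond the scatter, so compound 4 is expected to give 650 nM (range 200 nM to 2500 nM), a step of a 1.6-fold higher number from compound 1 to compound 4 (0.19 log units; within the scatter) expected from compound 1.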

Compound 4, half-maximal inhibitory concentration: 1110 nM
Compound 4: middle estimate off by 1.7-fold (0.23 log units), on the low side, and the stated range covers the measured number.
By their numbers in this assay, from the lowest: compound 3; then compound 1; then compound 4. At a limit, below all of these: compound 2.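

Working notes: this methyl on an aromatic carbon, meta to a fused ring and para to a fused ring, is not silent in this assay, whereas the earlier steps spoke only to (vinylcarbonyl)amino and ((vinylcarbonyl)amino)methyl on another aromatic carbon: hydrogen in place of methyl gives a 2.7-fold higher number from compound 1 to compound 4 (0.43 log units; beyond the scatter). The change is modest but beyond the scatter, and it is small beside the gain at that other carbon, seen in a 690-fold lower number from compound 1 to compound 3 (2.84 log units; beyond the scatter). Nothing measured here accounts for the loss on removing this methyl.

Open at this position is whether a longer chain such as ethyl, or a methoxy group, chlorine or fluorine, would keep, improve or further weaken the activity that methyl gives in compound 1. Also open, on these data alone, is whether hydrogen in place of methyl carries over to compound 3, at 0.6 nM, or whether the contribution of this methyl differs once ((vinylcarbonyl)amino)methyl is present.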